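The source may hold more compounds than are shown below. What is called first, only, known or untested is meant among the compounds shown, and "the series" means these compounds.

Compound 1 `O=C1c2ccccc2C(=O)N1C1C=C(C#Cc2ccccn2)CCC1` gives 27 nM in an in vitro functional assay on Ltk cells for inhibition of metabotropic glutamate receptor 5 (Homo sapiens), read by calcium flux; a lower number here means a stronger inhibitor, a higher number a weaker inhibitor.
Compound 2 `O=C(Oc1ccccc1)N1CC=C(C#Cc2ccccn2)CC1` gives 35 nM in this assay.
Compound 3 `O=S(=O)(Cc1ccccc1)N1CC=C(C#Cc2ccccn2)CC1` gives 58 nM in this assay.

Compound 3 stands at the highest of the three numbers in this assay. Compound 2 lies within the scatter of it, while compound 1 lies beyond the scatter below it. Compound 4 `O=S(=O)(c1ccc(Br)cc1)N1CC=C(C#Cc2ccccn2)CC1` differs from compound 3 by 4-bromophenyl in place of benzyl on a sulfonyl sulfur. Within the data shown here, no measured pair among the three compounds shares this change, so nothing measured tells how large a step it brings. Given that all three values fall in a narrow band, compound 4 is expected to stay near compound 3, with a step of a 1.2-fold lower number from compound 3 to compound 4 (0.06 log units; within the scatter) that does not go beyond the scatter in either direction. Compound 4 is therefore estimated at 50 nM, within a range from 20 nM to 130 nM.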

Compound 4, half-maximal inhibitory concentration: 2.2 nM
Estimate against measurement, compound 4: 23-fold (1.36 log units) above; the measured number lies below the stated range.
By their numbers in this assay, from the lowest: compound 4; then compounds 1, 2 and 3 (each within the scatter of the next, the first and the last beyond it).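

In this assay, among these compounds, 4-bromophenyl in place of benzyl on a sulfonyl sulfur brings a 26-fold lower number from compound 3 to compound 4 (1.42 log units; beyond the scatter) and so shows that this position can move the number strongly, which the earlier compounds, linked by no single change, could not show. The two groups match in heavy-atom count and in hydrogen-bond donors and acceptors, and each holds one six-membered aromatic ring of carbon only, so these counts do not separate them. No measured evidence bears on the size of this step.

The compounds shown leave open whether the step comes from the bromine or from losing the benzyl carbon chain link. A plain phenyl or a 4-chlorophenyl on the sulfonyl sulfur would separate these two readings.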